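The source may hold more compounds than are shown below. What is called first, only, known or untested is meant among the compounds shown, and "the series" means these compounds.

Measured so far in a functional assay on HeLa cells (Homo sapiens) for cytotoxicity, read by WST assay, with a stated time of 48 h; a higher number here means a weaker inhibitor, a lower number a stronger inhibitor:
- Compound 1 `O[C@@H](c1ccccc1)[C@H]1CO[C@H](c2ccccc2)[C@@H](C/C=C/c2ccccc2)C1`: 6060 nM
- Compound 2 `COc1ccc(/C=C/C[C@H]2C[C@@H]([C@@H](O)c3ccccc3)CO[C@@H]2c2ccccc2)cc1`: 8300 nM
- Compound 3 `Oc1cccc(/C=C/C[C@H]2C[C@@H]([C@@H](O)c3ccccc3)CO[C@@H]2c2ccccc2)c1`: 18600 nM

Compound 3 has the highest number of the three, so it is the weakest inhibitor here, with steps to both of the others beyond the scatter. The next compound, compound 4 `O[C@@H](c1ccccc1)[C@H]1CO[C@H](c2ccccc2)[C@@H](C/C=C/c2ccc(F)cc2)C1`, keeps the shared core and changes one group: 4-fluorophenyl in place of 3-hydroxyphenyl on a double-bonded chain carbon bound to a double-bonded chain carbon. In words, 4-fluorophenyl stands in place of 3-hydroxyphenyl on a double-bonded chain carbon bound to a double-bonded chain carbon.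

For the measured compounds named here, two measured steps bear most directly on this change. Adding the hydroxy gave a 3.1-fold higher number from compound 1 to compound 3 (0.49 log units; beyond the scatter), whereas adding the methoxy gave only a 1.4-fold higher number from compound 1 to compound 2 (0.14 log units; within the scatter). The step of a 2.2-fold higher number from compound 2 to compound 3 (0.35 log units; beyond the scatter) is similarly modest. Going by the values given here, no measured compound carries a fluorine, so that part of the change is untested. With the hydroxy gone, compound 4 is expected to return to the level of compound 1, at 6060 nM. The expected step is a 2.7-fold lower number from compound 3 to compound 4 (0.42 log units; beyond the scatter), a modest drop in the number in this assay. The estimate for compound 4 is 7000 nM, with an expected range of 3500 nM to 14000 nM.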

Compound 4, half-maximal inhibitory concentration: 8340 nM
Compound 4: the middle estimate sits 1.2-fold (0.08 log units) below what was measured; the range from low to high includes it.
By their numbers in this assay, from the lowest: compounds 1, 2 and 4 (each within the scatter of the next); then compound 3.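

In this assay, replacing 3-hydroxyphenyl with 4-fluorophenyl gives a 2.2-fold lower number from compound 3 to compound 4 (0.35 log units; beyond the scatter) and compound 3 is now the weakest inhibitor of the four, with all its steps beyond the scatter. Fluoro, seen here for the first time, cannot be told apart from hydrogen, with a 1.4-fold higher number from compound 1 to compound 4 (0.14 log units; within the scatter) and within the scatter, or from methoxy, with a 1.0-fold higher number from compound 2 to compound 4 (0.00 log units; within the scatter) and also within the scatter. No supporting evidence accompanies these numbers to explain why only the hydroxy compound stands apart.

On these data alone, it remains open whether an amine or a carboxylic acid on this ring would behave like the hydroxy of compound 3 or like the groups of compounds 1, 2 and 4. Also open, as far as these compounds go, is whether a longer chain carrying the same ring would shift the number at all.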